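Naphthyloxy acetamides: amide ring swap in the amino series

The compounds below may be only part of what the source reports. "The series", "measured", "known", "first", "only" and "open" are said of these compounds alone.

Two compounds of this series carry numbers in a functional assay on the whole organism with Mus musculus as the target, in the elevated plus maze, with a stated time of 24 h, at a dose of 3 mg/kg by the intraperitoneal route; on this read-out lower numbers stand for a weaker effect and higher numbers for a stronger effect at the one dose given. Compound 1 `O=C(COc1cccc2ccccc12)N1CCOCC1` gives 81.7% in this assay, and compound 2 `Nc1cccc2c(OCC(=O)N3CCCC3)cccc12` gives 74.5%. The two numbers lie within the usual scatter of each other, so no ordering of compound 1 and compound 2 can be read from them; compound 2 simply stands alongside compound 1.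

Compound 3 `Nc1cccc2c(OCC(=O)N3CCOCC3)cccc12` is not yet measured in this assay. It differs from compound 2 in one place: morpholin-4-yl in place of pyrrolidin-1-yl on a carbonyl carbon. For the measured compounds named here, no measured pair isolates exactly this change; compound 1 and compound 3 share the morpholin-4-yl amide, but compound 1 also lacks the amino group, so its number is only a loose guide. The step from compound 2 to compound 3 is expected to stay within the scatter, with no direction claimed, as a number 3.5 percentage points higher from compound 2 to compound 3 (within the scatter). Compound 3 is therefore expected to give about 78% in this assay, in the range 62% to 92%.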

Compound 3, a percentage reported as activity, at one dose (the size of the read-out at that dose, not a potency): 75.4%
For compound 3 the middle estimate is 2.6 percentage points above the measured one; low and high end bracket the measured number.
By their numbers in this assay, from the lowest: compounds 2, 3 and 1 (each within the scatter of the next).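

In this assay the amide ring swap now has a direct pair: with morpholin-4-yl in place of pyrrolidin-1-yl on a carbonyl carbon, the step of a number 0.9 percentage points higher from compound 2 to compound 3 (within the scatter) shows that this change leaves no readable difference at the one dose given. Compound 1 and compound 3 form a single-change pair as well: with amino in place of hydrogen on an aromatic carbon, the step of a number 6.3 percentage points lower from compound 1 to compound 3 (within the scatter) also leaves no readable difference. Nothing available bears on why either change behaves this way.

The one dose leaves open whether these compounds would separate at other doses. Also open, going by these compounds, is whether a piperidine or dimethylamine amide, an acetylated amine in place of the amino group, or a longer chain in place of the acetamide link would move the read-out beyond the scatter.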